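This account rests on a few compounds, and the source may have more. Where it says the series, first, only, none or still open, it means among the compounds named here.

Measured compounds in an assay on isolated protein (Cavia porcellus) with Sigma non-opioid intracellular receptor 1 (Homo sapiens) as the target, read by radioligand binding; a lower number here means a stronger inhibitor, a higher number a weaker inhibitor:
Compound 1 `CN(C)CCCCOc1ccc2oc(-c3ccccc3)cc(=O)c2c1` gives 400 nM.
Compound 2 `CN(C)CCCCCCCCOc1ccc2oc(-c3ccccc3)cc(=O)c2c1` gives 143 nM.

Going by the values given here, compound 2 stands at the lowest of the two numbers in this assay; its only neighbour is compound 1, with a higher number, and the gap between them is beyond the scatter. Compound 3 `CN(C)CCCCCCCCCCOc1ccc2oc(-c3ccccc3)cc(=O)c2c1` has not yet been measured. It differs from compound 2 by 2-(dimethylamino)ethyl in place of dimethylamino on a saturated chain carbon, eight bonds along the chain from an oxygen on an aromatic ring, which extends the chain between the oxygen on the aromatic ring and the dimethylamino group by two further carbons.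

Among the compounds with values here, one measured step bears on this: a 2.8-fold lower number from compound 1 to compound 2 (0.45 log units; beyond the scatter), where lengthening the same chain gave a modest drop in the number. On that basis a further, smaller drop in this assay is expected, a 1.5-fold lower number from compound 2 to compound 3 (0.18 log units; within the scatter), though a single step is thin ground for extrapolation. Compound 3 is therefore estimated at 95 nM, within a range of 40 nM to 250 nM.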

Compound 3, half-maximal inhibitory concentration: 341 nM
For compound 3 the middle estimate is 3.6-fold (0.56 log units) below the measured one; measured number outside the range, above it.
By their numbers in this assay, from the lowest: compound 2; then compounds 3 and 1 (each within the scatter of the next).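

Lengthening the chain does not keep lowering the number: in this assay, 2-(dimethylamino)ethyl in place of dimethylamino, on a saturated chain carbon eight bonds along the chain from an oxygen on an aromatic ring, gives a 2.4-fold higher number from compound 2 to compound 3 (0.38 log units; beyond the scatter). The longer chain thus gives back the earlier gain, and the full change in chain length gives a 1.2-fold lower number from compound 1 to compound 3 (0.07 log units; within the scatter), so among these three compounds the response to chain length is not monotonic and compound 2 holds the lowest number. Nothing available accounts for this turn.

The compounds shown leave open where the lowest number falls among chains of other lengths, and whether a chain longer than that of compound 3 raises the number further. They also leave open whether a piperidine or a morpholine in place of the dimethylamino group would follow the same pattern.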